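The source may report more compounds than this note shows. Statements on the series, on what has been measured and on what is new or still open speak of the compounds shown alone.

Three compounds share one core and differ only in the aromatic group attached to a saturated chain carbon. Compound 1 `Cc1cn2cc(C[C@H](C)CN3C[C@@H]4CCCC[C@@H]4[C@H](C(=O)N4CCN(c5ccc(F)c(F)c5)CC4)C3)ccc2n1` gives 107 nM in an assay on isolated protein for binding affinity to somatostatin receptor type 3 (Homo sapiens); on this read-out lower numbers stand for tighter binding and higher numbers for weaker binding. Compound 2 `C[C@@H](Cc1ccc2nccnc2c1)CN1C[C@@H]2CCCC[C@@H]2[C@H](C(=O)N2CCN(c3ccc(F)c(F)c3)CC2)C1` gives 10.7 nM. Compound 3 `CCOc1ccc(C[C@H](C)CN2C[C@@H]3CCCC[C@@H]3[C@H](C(=O)N3CCN(c4ccc(F)c(F)c4)CC3)C2)cn1` gives 14.1 nM, which places it second highest of the three numbers, close to compound 2 and far from compound 1. The steps show a 10-fold lower number from compound 1 to compound 2 (1.00 log units; beyond the scatter), a 7.6-fold lower number from compound 1 to compound 3 (0.88 log units; beyond the scatter) and a 1.3-fold higher number from compound 2 to compound 3 (0.12 log units; within the scatter). Compound 4 `CCNc1ccc(C[C@H](C)CN2C[C@@H]3CCCC[C@@H]3[C@H](C(=O)N3CCN(c4ccc(F)c(F)c4)CC3)C2)cn1` keeps everything of compound 3 except one change: ethylamino in place of ethoxy on an aromatic carbon. For the measured compounds named here, no measured step tests this exact swap; the steps that exist replace the whole aromatic group, and of those, the two six-membered-ring groups in compound 2 and compound 3 land within the scatter of each other. Since the change from compound 3 to compound 4 is smaller than any measured step, the expectation for compound 4 is a step of a 1.1-fold lower number from compound 3 to compound 4 (0.04 log units; within the scatter), that is, no change beyond the scatter. Compound 4 is therefore estimated at 13 nM, with a range from 4 nM to 45 nM.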

Compound 4, dissociation constant: 28.8 nM
Compound 4: the middle estimate sits 2.2-fold (0.35 log units) below what was measured, within the range that was stated.
By their numbers in this assay, from the lowest: compounds 2 and 3 (each within the scatter of the next); then compound 4; then compound 1.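

In this assay, for the compounds shown here, the swap of the linking oxygen of ethoxy for the nitrogen of ethylamino, with the same heavy-atom count and one hydrogen-bond donor brought in, is the first change tested at this single place on the aromatic ring, and it is not silent (a 2.0-fold higher number from compound 3 to compound 4 (0.31 log units; beyond the scatter)). The small swap also opens a gap to the quinoxalin-6-yl group that ethoxy did not show (a 2.7-fold higher number from compound 2 to compound 4 (0.43 log units; beyond the scatter)), while the new group still keeps a lower number than the two-ring group it is set against (a 3.7-fold lower number from compound 1 to compound 4 (0.57 log units; beyond the scatter)). No measurement shown here bears on the reason for these steps.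

As far as these compounds go, a dimethylamino group at this place would separate the nitrogen from its hydrogen, and that remains open. Methylamino or a longer propylamino chain would show how much the ethyl part counts.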